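Adding a second fluoro to compound 3

The compounds below may be only part of what the source reports. "The series", "measured", "known", "first", "only" and "open" are said of these compounds alone.

Measured in an ADME assay on Vero cells (Chlorocebus sabaeus) for cytotoxicity, read by MTT assay, with a stated time of 72 h; on this read-out higher numbers stand for an effect only at larger amounts of compound and lower numbers for an effect already at smaller amounts
compound 1 `O=C(Nc1nc(-c2ccccn2)cs1)c1ccccc1Cl` gives 2000 nM
compound 2 `O=C(Nc1nc(-c2ccccn2)cs1)c1ccccc1F` gives "not determined" (no result reported)
compound 3 `O=C(Nc1nc(-c2ccccn2)cs1)c1cccc(F)c1` gives 1200 nM

Going by the values given here, only two of the three compounds carry a number, since compound 2 has no reported result. Compound 3 at 1200 nM stands within the scatter of compound 1 at 2000 nM and the two cannot be ranked on these data.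

Compound 4 `O=C(Nc1nc(-c2ccccn2)cs1)c1cc(F)ccc1F` has not yet been measured. It differs from compound 3 by fluoro in place of hydrogen on an aromatic carbon and this fluoro in place of hydrogen sits on an aromatic carbon of a six-membered aromatic ring of carbon only, ortho to a large group and para to a fluoro group.

Among the compounds with values here, one measured step bears on this change, and only loosely. It runs a 1.7-fold lower number from compound 1 to compound 3 (0.22 log units; within the scatter) and stays within the scatter. Within the data shown here, no measured pair shows a fluoro added on its own, so the evidence for this change is thin. Among the measured compounds shown here, with that small step as the only guide, the expected change is a 1.1-fold higher number from compound 3 to compound 4 (0.03 log units; within the scatter) and no shift beyond the scatter is expected in either direction.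

In this assay compound 4 is estimated at 1300 nM (expected range 550 nM to 3000 nM).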

Compound 4, half-maximal effective concentration: 3300 nM
Estimate against measurement, compound 4: 2.5-fold (0.40 log units) below, and the stated range ends below it.
By their numbers in this assay, from the lowest: compounds 3, 1 and 4 (each within the scatter of the next, the first and the last beyond it).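

In this assay, going by these compounds alone, fluoro in place of hydrogen on an aromatic carbon, ortho to a large group and para to a fluoro group, gives a 2.8-fold higher number from compound 3 to compound 4 (0.44 log units; beyond the scatter) and is the first pair to show a fluoro added on its own. Within the data shown here, the change is modest but beyond the scatter, whereas the only earlier step, a 1.7-fold lower number from compound 1 to compound 3 (0.22 log units; within the scatter), stays within it, so this position is the first place where a single change moves the number, here towards an effect only at larger amounts of compound. Nothing measured on these compounds accounts for the shift, and it stands as an observation on one pair without an explanation.

Compound 2 carries a single fluoro on the ring but has no number to compare, so the series does not separate the effect of this position alone from that of the two fluoro groups together. As far as these compounds go, whether a methoxy group, an amine or a carboxylic acid on this same aromatic carbon would move the number in the same direction also remains open.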